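From compound 3 to compound 4 at the assay limit

A few compounds are considered here, and "the series" means these few. Any claim that something is new, unique, unknown or untested is made for them only; others in the source may bear on it.

In a functional assay on HepG2 cells (Homo sapiens) for antiproliferative activity, read by MTT assay, with a stated time of 48 h (a higher number here means a weaker inhibitor, a lower number a stronger inhibitor), compound 3 (`CCC(C)C(NC(=O)c1ccc(C(CC)(CC)c2ccc(OCCC(O)(CC)CC)c(C)c2)n1CC)C(=O)OC`) gives > 50000 nM which is a limit of the assay and not a number. Compound 1 (`CCn1c(C(=O)Nc2ccc(OC(F)(F)F)cc2)ccc1C(CC)(CC)c1ccc(OCCC(O)(CC)CC)c(C)c1`) gives > 50000 nM which is also a limit. Compound 2 (`CCOc1ccc(NC(=O)c2ccc(C(CC)(CC)c3ccc(OCCC(O)(CC)CC)c(C)c3)n2CC)cc1`) gives > 50000 nM which is also a limit. All three measured compounds therefore stand at the same limit (the limit of > 50000 nM in this assay, at which 3 of the 3 values shown sit) and none can be ranked against another.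

Compound 4 (`CCn1c(C(=O)N(C)CCO)ccc1C(CC)(CC)c1ccc(OCCC(O)(CC)CC)c(C)c1`) carries (2-hydroxyethyl)(methyl)amino on the carbonyl carbon, and the change is a group of 5 heavy atoms (3 carbon, 1 nitrogen, 1 oxygen; no ring) in place of a group of 10 heavy atoms (7 carbon, 1 nitrogen, 2 oxygen; no ring), on a carbonyl carbon in this series.

The measured steps bearing on it are a step that the two limits leave unreadable from compound 1 to compound 3 and a step that the two limits leave unreadable from compound 2 to compound 3 and both alter the group attached through the amide-type nitrogen. Neither gives a size to carry over, so no direction can be expected in this assay from them. The expected change is a number no higher from compound 3 to compound 4 (the limit leaves the size open) as an estimate only. For compound 4 the estimated value is 50000 nM with an expected range of 20000 nM to 100000 nM and another limit is the likeliest report.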

Compound 4, half-maximal inhibitory concentration: 510 nM
Compound 4: middle estimate off by 98-fold (1.99 log units), on the high side; measured number below the stated range.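

In this assay the group on the carbonyl carbon now separates compounds in this series: (2-hydroxyethyl)(methyl)amino gives an at least 98-fold lower number from compound 3 to compound 4 (1.99 log units; beyond the scatter) in place of a group with no ring. The same entering group gives an at least 98-fold lower number from compound 2 to compound 4 (1.99 log units; beyond the scatter) in place of (4-ethoxyphenyl)amino and an at least 98-fold lower number from compound 1 to compound 4 (1.99 log units; beyond the scatter) in place of (4-(trifluoromethoxy)phenyl)amino, so the change reads the same whether the leaving group carries an aromatic ring or none. The steps among compound 1, compound 2 and compound 3 cannot be read, all three standing at one limit: the limit of > 50000 nM in this assay, at which 3 of the 4 values shown sit.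

The compounds shown do not separate the contribution of the 2-hydroxyethyl chain from that of the methyl on the nitrogen. From the compounds shown here alone, how a longer chain, or an amine or a carboxylic acid in place of the hydroxyl, would read in this assay remains open.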